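The compounds below may be only part of what the source reports. "The series", "measured", "known", "first", "only" and "open" are said of these compounds alone.

Two related compounds have been tested so far in an ADME assay on HEK-293T cells (Homo sapiens) for inhibition, read by CCK-8 assay, with a stated time of 48 h, tested at 20 uM; a higher number here means more inhibition of growth at the concentration tested, a lower number less inhibition of growth. In that test, compound 1 (`N#C/C(=C\c1ccccc1OS(=O)(=O)c1ccccc1[N+](=O)[O-])C(=O)Nc1nnc(Cc2ccccc2)s1`) gives 10% and compound 2 (`Cc1ccc(S(=O)(=O)Oc2ccccc2/C=C(\C#N)C(=O)Nc2nnc(Cc3cccc(F)c3)s2)cc1`) gives 9%. These two numbers lie within the usual scatter of repeated measurements, so compound 2 stands level with compound 1 and neither can be ranked over the other. Both numbers show little inhibition of growth at the concentration tested.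

Compound 3 (`N#C/C(=C\c1ccccc1OS(=O)(=O)c1ccccc1[N+](=O)[O-])C(=O)Nc1nnc(Cc2cccc(F)c2)s1`) is compound 2 with a single change: 2-nitrophenyl in place of 4-methylphenyl on a sulfonyl sulfur. For the measured compounds named here, no measured pair isolates this swap, so its effect has not been seen directly. The closest clue is compound 1, which also carries 2-nitrophenyl on its sulfonyl sulfur and gives 10%, although it differs from compound 3 elsewhere too. On that basis, no step beyond the scatter is expected in this assay, and no direction is favoured. The expected change is a number 1 percentage points higher from compound 2 to compound 3 (within the scatter), a small step that stays within the scatter. For compound 3 the estimated value is 10%, with a range of 3% to 20%.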

Compound 3, percent growth inhibition at one concentration: "not toxic" (no number reported)
Compound 3 has no reported number here; no gap can be computed for the estimate.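

In this assay, for the compounds shown here, compound 3 carries a verbal result without a number, so no step from compound 2 to compound 3 can be read. No other data here bear on this result. On these data alone, whether 2-nitrophenyl in place of 4-methylphenyl on the sulfonyl sulfur shifts growth inhibition at all remains open.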